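This account rests on a few compounds, and the source may have more. Where it says the series, first, only, none or still open, it means among the compounds named here.

Among the measured compounds shown here, in a functional assay (aorta) with Rattus norvegicus as the target (on this read-out higher numbers stand for weaker inhibition and lower numbers for stronger inhibition), only two compounds have numbers so far. Compound 1 `CC1(C)Oc2ccc(C#N)cc2[C@@H](/N=C(\NC#N)NCc2ccccc2)[C@@H]1O`, with benzyl on an amine nitrogen, gives 2400 nM. Compound 2 `Cc1cccc(N/C(=N/[C@@H]2c3cc(C#N)ccc3OC(C)(C)[C@H]2O)NC#N)c1`, with 3-methylphenyl in that place, gives 1000 nM, which is the lower of the two numbers and so the stronger inhibition. The measured step is a 2.4-fold lower number from compound 1 to compound 2 (0.38 log units; beyond the scatter), modest but beyond the scatter.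

The next compound to test is compound 3 `Cc1ccc(N/C(=N/[C@@H]2c3cc(C#N)ccc3OC(C)(C)[C@H]2O)NC#N)cc1`. It has the same atoms as compound 2, joined differently: 4-methylphenyl in place of 3-methylphenyl on an amine nitrogen. In words, 4-methylphenyl stands in place of 3-methylphenyl on the amine nitrogen.

For the measured compounds named here, only one measured step can serve as a guide, and it is a different exchange, benzyl to 3-methylphenyl. Going by the values given here, no measured pair compares two methylphenyl groups, so the data favour no direction here. Among the compounds with values here, the step seen with compound 2, a 2.4-fold lower number from compound 1 to compound 2 (0.38 log units; beyond the scatter), suggests only that changes at this nitrogen can be modest. In this assay, no step beyond the scatter is therefore expected. The estimated step is a 1.1-fold higher number from compound 2 to compound 3 (0.04 log units; within the scatter). Compound 3 is expected at about 1100 nM, with an estimated range of 400 nM to 3000 nM.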

Compound 3, half-maximal inhibitory concentration: 2700 nM
Estimate against measurement, compound 3: 2.5-fold (0.39 log units) below; measured number inside the range.
By their numbers in this assay, from the lowest: compound 2; then compounds 1 and 3 (each within the scatter of the next).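

In this assay, the place of the methyl group on the phenyl ring turns out to matter: 3-methylphenyl and 4-methylphenyl have the same heavy atoms, yet exchanging one for the other on the amine nitrogen gives a 2.7-fold higher number from compound 2 to compound 3 (0.43 log units; beyond the scatter) at that nitrogen. The other new step, a 1.1-fold higher number from compound 1 to compound 3 (0.05 log units; within the scatter) with 4-methylphenyl in place of benzyl, shows that swapping benzyl for a methylphenyl group does not by itself lower the number, so among these three groups the lower number belongs to 3-methylphenyl alone. Nothing available here explains why the two methylphenyl groups differ and the result stands as an observation only.

As far as these compounds go, what remains open is whether the methyl group itself matters, which plain phenyl on the same nitrogen would help to show, and how 2-methylphenyl would compare with the two groups seen here. From the compounds shown here alone, it is also open whether a different group in the same place on the ring, such as the chlorine of 3-chlorophenyl or the methoxy of 3-methoxyphenyl, would keep the number as low as in compound 2.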